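This account rests on a few compounds, and the source may have more. Where it says the series, first, only, none or still open, it means among the compounds named here.

Measured so far:
compound 1 `CO[C@@H]1[C@@H](O)[C@H](Oc2ccc3ccccc3c2)OC[C@H]1O` — 17 uM
compound 2 `O[C@@H]1[C@@H](O)[C@H](Oc2ccc3ccccc3c2)OC[C@H]1F` — 32 uM

In an ADME assay on CCD-1095SK cells (Homo sapiens) for antiproliferative activity, read by crystal violet staining, with a stated time of 96 h (a lower number here means that less compound is needed, a higher number that more compound is needed for the effect), compound 1 gives 17 uM and compound 2 gives 32 uM; the two numbers lie within the scatter of each other, so neither can be called the more potent. Compound 1 holds the lower of the two numbers and is the point of departure for compound 3 `O[C@@H]1CO[C@@H](Oc2ccc3ccccc3c2)[C@H](O)C1`, which has not yet been run in this assay. The change from compound 1 to compound 3 is hydrogen in place of methoxy on a saturated ring carbon. Going by the values given here, no pair of measured compounds shows this change, so there is no measured step to lean on; the small size of the group that leaves gives no ground to expect a large move in this assay, and a step from compound 1 to compound 3 of a 1.8-fold higher number from compound 1 to compound 3 (0.25 log units; within the scatter) is expected, at or near the edge of the scatter, toward a higher number. For compound 3 a value of 30 uM is estimated, with a range of 10 uM to 90 uM.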

Compound 3, concentration for half-maximal effect: 79 uM
Estimate against measurement, compound 3: 2.6-fold (0.42 log units) below, within the range that was stated.
By their numbers in this assay, from the lowest: compounds 1 and 2 (each within the scatter of the next); then compound 3.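

In this assay, going by these compounds alone, the methoxy on this saturated ring carbon counts for something: hydrogen in its place gives a 4.6-fold higher number from compound 1 to compound 3 (0.67 log units; beyond the scatter), a modest step but one beyond the scatter, which the earlier compounds could not show. The position, next to two ring atoms that each bear a hydroxy group, therefore responds to what it carries, and here the loss of the methoxy raises the number. Nothing measured bears on why the number rises.

This single step does not separate the oxygen of the methoxy from its methyl, and a hydroxy group on this carbon would address that, while an ethoxy group or an amine would test how far the position accepts other groups. Compound 2 differs from compound 1 in more than one place, so it gives no separate reading on this carbon.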